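Swapping one aromatic group on the shared core

A few compounds are considered here, and "the series" means these few. Any claim that something is new, unique, unknown or untested is made for them only; others in the source may bear on it.

Compound 1 `CCN1C(=O)CSC1c1cccc(C(=O)NCCCCc2ccccc2)c1` > 1000 nM (a limit)
Compound 2 `O=C(NCCCCc1ccccc1)c1cccc(C2SCC(=O)N2c2ccccc2F)c1` 34.1 nM
Compound 3 `CC(F)(F)c1cccc(N2C(=O)CSC2c2cccc(C(=O)NCCCCc3ccccc3)c2)c1` 29.1 nM

The compounds were tested in a functional assay on HOS-TE85 cells (Homo sapiens) for inhibition, read by CCK-8 assay, with a stated time of 72 h; a lower number here means a stronger inhibitor, a higher number a weaker inhibitor. For compound 1 the entry > 1000 nM is a limit of the assay and not a number. Compound 3 gives 29.1 nM, and it stands level with compound 2 , since a 1.2-fold lower number from compound 2 to compound 3 (0.07 log units; within the scatter) lies within the scatter.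

Compound 4 `COc1ccc(N2C(=O)CSC2c2cccc(C(=O)NCCCCc3ccccc3)c2)c(OC)c1` differs from compound 3 in one group: a group of 10 heavy atoms (8 carbon, 2 oxygen; one six-membered aromatic ring of carbon only) in place of a group of 10 heavy atoms (8 carbon, 2 fluorine; one six-membered aromatic ring of carbon only), on an amide-type nitrogen in a ring. The group that enters is 2,4-dimethoxyphenyl, on an amide-type nitrogen in a ring.

Two measured steps show how much that place can matter: an at least 29-fold lower number from compound 1 to compound 2 (1.46 log units; beyond the scatter) and an at least 34-fold lower number from compound 1 to compound 3 (1.53 log units; beyond the scatter). Both put a six-membered aromatic ring of carbon only in place of a small group, and compound 4 keeps such a ring. Changing what that ring carries made no difference beyond the scatter in a 1.2-fold lower number from compound 2 to compound 3 (0.07 log units; within the scatter). Neither measured ring carries oxygen, so this comparison is loose.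

Going by these compounds, no step beyond the scatter is therefore expected in this assay, and the direction remains open. The expected step is a 1.5-fold higher number from compound 3 to compound 4 (0.19 log units; within the scatter). For compound 4 the estimated value is 45 nM, with an expected range from 12 nM to 200 nM.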

Compound 4, half-maximal inhibitory concentration: 90.4 nM
The estimate for compound 4 lay 2.0-fold (0.30 log units) below the measured number; the measured number falls inside the stated range.
By their numbers in this assay, from the lowest: compounds 3 and 2 (each within the scatter of the next); then compound 4. At a limit, above all of these: compound 1.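

Compounds 2 and 3 made what the aromatic ring carries look unimportant, but compound 4 shows that it can matter on this amide-type nitrogen in this assay: there is a 3.1-fold higher number from compound 3 to compound 4 (0.49 log units; beyond the scatter) and a 2.7-fold higher number from compound 2 to compound 4 (0.42 log units; beyond the scatter). Even so, 2,4-dimethoxyphenyl stays far ahead of ethyl, with an at least 11-fold lower number from compound 1 to compound 4 (1.04 log units; beyond the scatter), so among these compounds having the aromatic ring counts for more than what it carries. The entry for compound 1 is a limit of the assay and not a number, so the full size of that last step stays unknown: the limit of > 1000 nM in this assay, at which 1 of the 4 values shown sits.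

The compounds shown do not tell which of the two methoxy groups accounts for the weaker number of compound 4. Going by these compounds, how a ring bearing an amine or a carboxylic acid would read here also remains open.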